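The compounds below may be only part of what the source reports. "The series", "measured", "known", "first", "only" and "open" are said of these compounds alone.

Among the measured compounds shown here, compound 2 `Brc1ccc(-c2cc(CN(c3ncccn3)c3nc4ccccc4s3)on2)cc1` gives 21100 nM in a functional assay on MCF7 cells (Homo sapiens) for antiproliferative activity, read by MTT assay (a lower number here means a stronger inhibitor, a higher number a weaker inhibitor), the lower of the two numbers so far; compound 1 `COc1ccc(-c2cc(CN(c3ncccn3)c3nc4ccccc4s3)on2)cc1` gives 30700 nM. For the measured compounds named here, the one step measured, a 1.5-fold lower number from compound 1 to compound 2 (0.16 log units; within the scatter), swaps a substituent on the same phenyl ring and stays within the scatter. Compound 3 `Fc1ccccc1-c1cc(CN(c2ncccn2)c2nc3ccccc3s2)on1` differs from compound 2 by 2-fluorophenyl in place of 4-bromophenyl on an aromatic carbon. Going by the values given here, this change bears on the same phenyl ring, and the only precedent, a 1.5-fold lower number from compound 1 to compound 2 (0.16 log units; within the scatter), moved little, so no step beyond the scatter is expected in this assay. Compound 3 is therefore estimated at 25000 nM, range 8000 nM to 70000 nM, an expected step of a 1.2-fold higher number from compound 2 to compound 3 (0.07 log units; within the scatter).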

Compound 3, half-maximal inhibitory concentration: 19500 nM
The estimate for compound 3 lay 1.3-fold (0.11 log units) above the measured number; low and high end bracket the measured number.
By their numbers in this assay, from the lowest: compounds 3, 2 and 1 (each within the scatter of the next).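

At the aromatic carbon next to the ring nitrogen, 2-fluorophenyl in place of 4-bromophenyl changes both the halogen and its ring position, yet this assay shows a 1.1-fold lower number from compound 2 to compound 3 (0.03 log units; within the scatter) and no separation. 2-Fluorophenyl in place of 4-methoxyphenyl likewise gives a 1.6-fold lower number from compound 1 to compound 3 (0.20 log units; within the scatter), so all three substituted phenyl groups read alike at this position. No evidence on hand explains this closeness.

From the compounds shown here alone, whether any change at this position can move the number beyond the scatter remains open. An amine or a carboxylic acid on the phenyl ring would test this, as would a longer chain in its place.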